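This account rests on a few compounds, and the source may have more. Where it says the series, first, only, none or still open, it means among the compounds named here.

Measured so far in a functional assay on HCC1937 cells (Homo sapiens) for antiproliferative activity, read by CCK-8 assay, with a stated time of 72 h; a lower number here means a stronger inhibitor, a higher number a weaker inhibitor: compound 1 `Cc1ccc(C(=O)Nc2cccc(-c3oc4cc(-c5ccc(F)cc5)ccc4c(=O)c3O)c2)cc1` gives 7110 nM; compound 2 `O=C(Nc1cccc(-c2oc3cc(-c4ccc(F)cc4)ccc3c(=O)c2O)c1)c1ccc(F)cc1F` gives 6980 nM.

Going by the values given here, compound 2 and compound 1 lie within the scatter of each other, so neither stands apart on the numbers so far. Among the compounds with values here, the one step measured, a 1.0-fold lower number from compound 1 to compound 2 (0.01 log units; within the scatter), shows that swapping the aryl group on the carbonyl carbon left the number unchanged. Compound 3 `O=C(Nc1cccc(-c2oc3cc(-c4ccc(F)cc4)ccc3c(=O)c2O)c1)c1ccc(Br)cc1` makes the same kind of swap: 4-bromophenyl in place of 2,4-difluorophenyl on a carbonyl carbon. Within the data shown here, with only that step to go on, no movement beyond the scatter is expected for compound 3 in this assay, a 1.1-fold lower number from compound 2 to compound 3 (0.03 log units; within the scatter). Compound 3 is accordingly estimated at 6500 nM, with a range from 3000 nM to 15000 nM.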

Compound 3, half-maximal inhibitory concentration: 8630 nM
Beside the measured number, compound 3's estimate is 1.3-fold (0.12 log units) below it, within the range that was stated.
By their numbers in this assay, from the lowest: compounds 2, 1 and 3 (each within the scatter of the next).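

In this assay a heavier halogen joins the set: 4-bromophenyl in place of 2,4-difluorophenyl on a carbonyl carbon gives a 1.2-fold higher number from compound 2 to compound 3 (0.09 log units; within the scatter) and bromo in place of methyl on an aromatic carbon gives a 1.2-fold higher number from compound 1 to compound 3 (0.08 log units; within the scatter) as its reading. Three different aryl groups at this place now lie within the scatter of one another, so no separation has appeared among them. No supporting measurement speaks to the reason for this flat reading.

As far as these compounds go, whether any group at this place moves the number beyond the scatter stays open. A phenyl carrying an amine or a carboxylic acid, or a longer alkyl chain, would test that.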